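The source may hold more compounds than are shown below. What is called first, only, known or untested is meant among the compounds shown, and "the series" means these compounds.

Measured compounds, all in a functional assay on MCF7 cells (Homo sapiens) for antiproliferative activity, read by MTT assay, with a stated time of 72 h; on this read-out lower numbers stand for stronger inhibition and higher numbers for weaker inhibition:
- compound 1 `C=CC(=O)Nc1cc2c(N3CCc4ccccc43)ncnc2cc1OC` gives 11700 nM
- compound 2 `COc1cc2ncnc(N3CCc4ccccc43)c2cc1NC(=O)/C=C/C(C)C` gives 6780 nM
- compound 3 `COc1cc2ncnc(N3CCc4ccccc43)c2cc1NC(=O)/C=C/CN1CCCCC1` gives 1680 nM

Compound 3 stands lowest of the three numbers. From compound 1, 3-(piperidin-1-yl)prop-1-en-1-yl in place of vinyl on the carbonyl carbon gave a 7.0-fold lower number from compound 1 to compound 3 (0.84 log units; beyond the scatter); from compound 2, (piperidin-1-yl)methyl in place of isopropyl gave a 4.0-fold lower number from compound 2 to compound 3 (0.61 log units; beyond the scatter). Both steps lie beyond the scatter, so compound 3 is the most potent of the three in this assay. The step between the two weaker compounds, a 1.7-fold lower number from compound 1 to compound 2 (0.24 log units; within the scatter), stays within the scatter.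

Compound 4 `COc1cc2ncnc(N3CCc4ccccc43)c2cc1NC(=O)/C=C/CN1CCN(C)CC1` differs from compound 3 by 4-methylpiperazin-1-yl in place of piperidin-1-yl on a saturated chain carbon bound to a double-bonded chain carbon. Among the measured compounds shown here, no measured step exchanges one saturated ring for another at this position. For the measured compounds named here, the steps that bear on it, a 4.0-fold lower number from compound 2 to compound 3 (0.61 log units; beyond the scatter) and a 7.0-fold lower number from compound 1 to compound 3 (0.84 log units; beyond the scatter), show only that a chain end carrying such a ring lowered the number, and compound 4 keeps a chain end of that kind. Hence no step beyond the scatter is expected in this assay from compound 3 to compound 4, a 1.1-fold lower number from compound 3 to compound 4 (0.05 log units; within the scatter), in either direction. Compound 4 is estimated at 1500 nM, with a range of 600 nM to 4000 nM.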

Compound 4, half-maximal inhibitory concentration: 6430 nM
Compound 4: the middle estimate sits 4.3-fold (0.63 log units) below what was measured, outside the stated range (above it).
By their numbers in this assay, from the lowest: compound 3; then compounds 4, 2 and 1 (each within the scatter of the next).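

In this assay the identity of the ring at this chain end matters, with 4-methylpiperazin-1-yl in place of piperidin-1-yl giving a 3.8-fold higher number from compound 3 to compound 4 (0.58 log units; beyond the scatter) on a saturated chain carbon bound to a double-bonded chain carbon. With the new ring, the chain end no longer stands apart from the simpler ones, as a 1.1-fold lower number from compound 2 to compound 4 (0.02 log units; within the scatter) and a 1.8-fold lower number from compound 1 to compound 4 (0.26 log units; within the scatter) both lie within the scatter. Among these four compounds, the lowering seen in the earlier steps therefore belongs to the piperidin-1-yl chain end and not to any chain end carrying a saturated ring, and compound 4 goes against that broader reading. Nothing at hand explains why the two rings differ.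

The compounds shown leave open whether the step follows the second ring nitrogen or its methyl, which a piperazin-1-yl with a free ring amine or a morpholin-4-yl at the same place would help to separate. They also leave open how a smaller ring such as pyrrolidin-1-yl or an open dimethylamino end would read in this series.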